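The source may hold more compounds than are shown below. What is called first, only, known or untested is meant among the compounds shown, and "the series" means these compounds.

The compounds here share one core, and the question is how a change at the amide end alters the number read in a functional assay on HeLa cells (Homo sapiens) for cytotoxicity, read by MTT assay, with a stated time of 24 h; a lower number here means a stronger inhibitor, a higher number a weaker inhibitor. Compound 1, `C=CC1=C(C(=O)NCCCCC)C(c2ccc(Cl)c(Cl)c2)OC1`, gives only a limit of the assay, namely > 100000 nM. Compound 2, `C=CC1=C(C(=O)NCc2ccc(C)cc2)C(c2ccc(OC)c(OC)c2)OC1`, likewise gives only a limit, > 100000 nM. Compound 3, `C=CC1=C(C(=O)O)C(c2ccc(OC)c(OC)c2)OC1`, gives a real number, 18000 nM. Among the compounds with values here, the one measured step that can be followed is an at least 5.5-fold lower number from compound 2 to compound 3 (0.74 log units; beyond the scatter); it changes the same carbonyl position but puts in a hydroxy rather than a different amine, so it bears only indirectly on the change considered now. Compound 4, `C=CC1=C(C(=O)NCc2ccccc2)C(c2ccc(Cl)c(Cl)c2)OC1`, differs from compound 1 by phenyl in place of butyl on a saturated chain carbon bound to an amide-type nitrogen. Compound 2 already carries a (4-methylbenzyl)amino group and sits at a limit, and two of the three values shown rest at the limit of > 100000 nM in this assay, at which 2 of the 3 values shown sit. The step is therefore expected to be small, a step that the limit leaves unreadable from compound 1 to compound 4. Compound 4 is accordingly expected to reach about 150000 nM in this assay, within a range from 30000 nM to 600000 nM.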

Compound 4, half-maximal inhibitory concentration: > 100000 nM
Compound 4 ended at the assay's limit; the forecaster's own chance of this, stated with the estimate: 75%; the middle value lies beyond the limit too.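

Compound 1 and compound 4 both sit at a limit of this assay rather than at a real number, so no step can be read between them: the limit of > 100000 nM in this assay, at which 3 of the 4 values shown sit.

The compounds shown leave open whether phenyl in place of butyl changes the number at all.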